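Changing the Aryl Group on the Sulfonamide of Compound 1

The compounds below may be only part of what the source reports. "The series", "measured", "known", "first", "only" and "open" are said of these compounds alone.

Within the data shown here, compound 1 `Cc1ccc(S(=O)(=O)N[C@H]2C3CC[C@H](C3)[C@@H]2C/C=C\CCCC(=O)O)cc1` carries a 4-methylphenyl on its sulfonyl sulfur, and in a functional assay (plasma) for inhibition, with Oryctolagus cuniculus as the target (on this read-out higher numbers stand for weaker inhibition and lower numbers for stronger inhibition), compound 1 gives 500 nM, the only single number in view. Compound 2 `O=C(O)CCC/C=C\C[C@H]1[C@@H]2CCC(C2)[C@@H]1NS(=O)(=O)c1ccccc1`, with a plain phenyl in that place, was measured repeatedly in this assay and compound 2 gives 1000 nM; 7400 nM; 600 nM (3 entries). Compound 3 `O=C(O)CCC/C=C\C[C@H]1[C@@H]2CCC(C2)[C@@H]1NS(=O)(=O)c1cccc2ccccc12` differs from compound 1 by naphthalen-1-yl in place of 4-methylphenyl on a sulfonyl sulfur. Among the measured compounds shown here, no measured pair shows what this change does, so only a small shift is expected, at most a modest gain beyond the scatter. Compound 3 is expected to give 300 nM in this assay, between 60 nM and 1500 nM. The expected step is a 1.7-fold lower number from compound 1 to compound 3 (0.22 log units; within the scatter).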

Compound 3, half-maximal inhibitory concentration: 1100 nM
For compound 3 the middle estimate is 3.7-fold (0.56 log units) below the measured one, within the range that was stated.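

In this assay, the step for naphthalen-1-yl in place of 4-methylphenyl on the sulfonyl sulfur is a 2.2-fold higher number from compound 1 to compound 3 (0.34 log units; beyond the scatter), so the second six-membered aromatic ring brings no gain and costs only a modest loss of inhibition. This position therefore accepts the two-ring group while inhibition stays in the same broad range. The step is small beside the spread of repeated results for one compound, so it needs cautious reading: the several entries of compound 2 in this assay, 1000 nM; 7400 nM; 600 nM (3 entries)

The compounds shown leave open how a methoxy group or an amine on the phenyl ring would change inhibition. They also leave open whether naphthalen-2-yl would behave like naphthalen-1-yl.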